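The source may report more compounds than this note shows. Statements on the series, on what has been measured and on what is new or still open speak of the compounds shown alone.

Working notes on the series. Compound 1 `Cc1ccccc1NNC(=O)c1ccccc1NS(=O)(=O)c1cnc(O)nc1O` is the starting point. In a functional assay on SGC-7901 cells (Homo sapiens) for antiproliferative activity, read by MTT assay, with a stated time of 24 h (a lower number here means a stronger inhibitor, a higher number a weaker inhibitor), compound 1 gives > 20000 nM, which is a limit of the assay and not a number. Compound 1 therefore stands at the limit of > 20000 nM in this assay, at which 1 of the 2 values shown sits, and nothing more than that limit is known for it.

Compound 2 `O=C(NNC(=O)c1cccc(NS(=O)(=O)c2cnc(O)nc2O)c1)c1cccc(Cl)c1` carries a carbonyl-linked chlorophenyl group on the amine nitrogen, on a core substituted differently from that of compound 1. In this assay compound 2 gives 7310 nM. Among the measured compounds shown here, no single-point step connects compound 1 and compound 2; their two values show only that compound 2 returns a number where compound 1 returns a limit.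

Compound 3 `O=C(NNC(=O)c1ccccc1NS(=O)(=O)c1cnc(O)nc1O)c1ccccc1Cl` has not yet been measured in this assay. Compound 3 differs from compound 1 by (2-chlorophenyl)carbonyl in place of 2-methylphenyl on an amine nitrogen. Compound 2 with its 7310 nM is the nearest guide, as it shares the carbonyl-linked chlorophenyl group. The step from compound 1 to compound 3 is expected to be an at least 2.0-fold lower number from compound 1 to compound 3 (0.30 log units; that floor lies within the scatter), downward from the limit, though it is estimated with wide uncertainty. Compound 3 is estimated at 10000 nM, with a range from 3000 nM to 30000 nM.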

Compound 3, half-maximal inhibitory concentration: 2410 nM
Compound 3: middle estimate off by 4.1-fold (0.62 log units), on the high side; the measured number lies below the stated range.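

Among the compounds shown here, on the amine nitrogen whose other neighbour is the amide-type nitrogen, (2-chlorophenyl)carbonyl in place of 2-methylphenyl gives the only single-point step so far in this assay: an at least 8.2-fold lower number from compound 1 to compound 3 (0.91 log units; beyond the scatter). This step lies beyond the scatter, so activity in this assay responds to the group at this position, which compound 1 and compound 2 could not show, as they differ in more than one place. The value of compound 1 is a limit and not a number, so the step gives only a floor for the size of the change: the limit of > 20000 nM in this assay, at which 1 of the 3 values shown sits.

The exchange brings in the carbonyl and the chlorine together and removes the methyl, so the compounds shown leave open which of these changes carries the step. As far as these compounds go, a (2-methylphenyl)carbonyl or an unsubstituted phenylcarbonyl group on the same nitrogen would separate these contributions, and how an amine or a carboxylic acid on that ring would read out in this assay also remains open.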